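The compounds below may be only part of what the source reports. "The series", "measured", "known", "first", "only" and "open" are said of these compounds alone.

Measured compounds:
- Compound 1 `CCCOC(=O)c1ccc(COC(COCc2ccc(OC)cc2)Cn2ccnc2)cc1`: 180 nM
- Compound 2 `COc1ccc(COCC(Cn2ccnc2)OCc2ccc(C(=O)Oc3ccccc3)cc2)cc1`: 560 nM
- Compound 3 `COc1ccc(COCC(Cn2ccnc2)OCc2ccc(C(=O)OCc3ccccc3)cc2)cc1`: 1490 nM

In a functional assay for inhibition of Thromboxane-A synthase (Homo sapiens) (a higher number here means a weaker inhibitor, a lower number a stronger inhibitor), compound 3 gives the highest number of the three, with compound 2 nearest and compound 1 furthest. Compound 4 `COc1ccc(COCC(Cn2ccnc2)OCc2ccc(C(=O)O)cc2)cc1` differs from compound 3 by hydrogen in place of benzyl on an oxygen next to a carbonyl group. All three measured steps change the group on that same oxygen: a 3.1-fold higher number from compound 1 to compound 2 (0.49 log units; beyond the scatter), an 8.3-fold higher number from compound 1 to compound 3 (0.92 log units; beyond the scatter) and a 2.7-fold higher number from compound 2 to compound 3 (0.42 log units; beyond the scatter). The propyl ester, compound 1, carries the lowest number, and each larger group on that oxygen went with a higher number. Within the data shown here, the step to a bare hydrogen has no direct counterpart here, so the expectation rests on this trend alone and is uncertain. Compound 4 is estimated to move down by a 4.3-fold lower number from compound 3 to compound 4 (0.63 log units; beyond the scatter), to about 350 nM, within 80 nM to 1500 nM.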

Compound 4, half-maximal inhibitory concentration: 6700 nM
Beside the measured number, compound 4's estimate is 19-fold (1.28 log units) below it; the measured number lies above the stated range.
By their numbers in this assay, from the lowest: compound 1; then compound 2; then compound 3; then compound 4.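

In this assay the free carboxy breaks the earlier trend, giving a 4.5-fold higher number from compound 3 to compound 4 (0.65 log units; beyond the scatter) as well as a 12-fold higher number from compound 2 to compound 4 (1.08 log units; beyond the scatter) and a 37-fold higher number from compound 1 to compound 4 (1.57 log units; beyond the scatter) when hydrogen replaces each ester group. Size alone therefore does not order this oxygen's substituents: hydrogen, the smallest, goes against the rise from propyl to phenyl to benzyl and gives the weakest inhibitor of the four. Nothing available here explains this reversal. From the compounds shown here alone, whether a methyl ester would give a lower number than the propyl ester stays open, as does whether an amide in place of the ester would track the esters or the free carboxy.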